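The source may report more compounds than this note shows. Statements on the series, on what has been measured and on what is new or still open speak of the compounds shown alone.

Working notes on the dienone series.

Compound 1 `COc1ccc(/C=C/C=C/C(=O)c2cc(Cl)ccc2O)cc1` is recorded in an in vitro assay on cells for inhibition of Amine oxidase [flavin-containing] A (Homo sapiens), read by Amplex Red, with a stated time of 15 min, tested at 100 uM (on this read-out higher numbers stand for more inhibition at the one concentration tested (going by the name of the read-out) and lower numbers for less inhibition), as "not active" (no number reported); no number stands against it, so it cannot be placed on the scale beyond being without measurable effect at the single concentration tested. Compound 2 `COc1ccc(/C=C/C=C/C(=O)c2ccccc2O)cc1`, which carries no chloro on the phenol ring, gives in this assay a value of 40%. For the measured compounds named here, no step between these two is computed, so their two values show only that the chloro-bearing compound 1 sits at no effect while compound 2 sits at moderate inhibition.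

Compound 3 `O=C(/C=C/C=C/c1ccccc1)c1cc(Cl)ccc1O` is the next point, not yet measured in this assay. The change from compound 1 is hydrogen in place of methoxy on an aromatic carbon. The chloro and the phenol are kept, so the number for compound 3 in this assay is expected to stay low, close to that of compound 1, which is reported as "not active" (no number reported). Starting from a compound reported without effect, the expected step in this assay is at most a small rise, quite possibly none beyond the scatter, with a real chance that again only a limit and no number is returned.

Compound 3 is estimated in this assay at 12%, within a range of 0% to 30%.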

Compound 3, a percentage reported as inhibition, at one concentration (the size of the read-out at that concentration, not a potency): "not active" (no number reported)
Compound 3: no number reported, and the estimate cannot be compared.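

In this assay compound 1 gives "not active" (no number reported) and compound 3 gives "not active" (no number reported), so no step can be read between them. The compounds shown leave open whether exchanging methoxy for hydrogen changes inhibition at all while the chloro is kept. No measured evidence bears on this result.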